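The source may hold more compounds than are shown below. What is called first, only, known or untested is meant among the compounds shown, and "the series" means these compounds.

The measured compounds in this study:

Compound 1, `Cc1cccc2cc(/C=C3\SC(=S)NC3=O)c(Cl)nc12`: > 100 ug/mL
Compound 2, `COc1ccc2cc(/C=C3\SC(=S)NC3=O)c(Cl)nc2c1`: > 100 ug/mL
Compound 3, `O=C1NC(=S)S/C1=C\c1cc2cc(F)ccc2nc1Cl`: > 100 ug/mL

In a toxicity assay on THP-1 cells (Homo sapiens) for cytotoxicity, read by MTT assay, with a stated time of 48 h (on this read-out higher numbers stand for weaker inhibition of growth and lower numbers for stronger inhibition of growth), compound 1 gives > 100 ug/mL, which is a limit of the assay and not a measured number. Compound 2 gives > 100 ug/mL, likewise a limit. Compound 3 gives > 100 ug/mL, again a limit. Compound 1 therefore stands at the limit of > 100 ug/mL in this assay, at which 3 of the 3 values shown sit, and nothing in these three results places any of them in order against the others.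

Compound 4, `Cc1cccc2cc(/C=C3\SC(=S)N(CC(=O)O)C3=O)c(Cl)nc12`, has not yet been measured in this assay. It differs from compound 1 in one place: carboxymethyl in place of hydrogen on an amide-type nitrogen in a ring. Among the measured compounds shown here, no pair of measured compounds differs by a single change, so no measured step is available for comparison. Since compound 1 gives only > 100 ug/mL in this assay, the expectation for compound 4 is that it remains at the limit as well, with no step beyond the usual scatter. Compound 4 is accordingly estimated at 150 ug/mL, with a range from 60 ug/mL to 400 ug/mL. The step that the limit leaves unreadable from compound 1 to compound 4 implied by this estimate is expected to be no change in practice.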

Compound 4, concentration for 50% growth inhibition: > 100 ug/mL
Compound 4 ended at the assay's limit; the forecaster's own chance of this, stated with the estimate: 80%; the middle value does not contradict the limit.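

Among the compounds shown here, compound 1 and compound 4 both stand only at a limit in this assay, so no step from compound 1 to compound 4 can be read. The compounds shown leave open how strongly any of them inhibits growth, and whether carboxymethyl in place of hydrogen on the amide-type nitrogen changes that, because all rest at one point: the limit of > 100 ug/mL in this assay, at which 4 of the 4 values shown sit.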